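Expected Cytotoxicity After Swapping a Ring for a Sulfonyl Group

The source may report more compounds than this note shows. Statements on the series, on what has been measured and on what is new or still open speak of the compounds shown alone.

Compound 1 `Cc1cc(C)cc(S(=O)(=O)c2c(C(=O)N[C@H]3CCNC3)[nH]c3ccc(Cl)cc23)c1` has the lowest number of those shown: in an ADME assay on MT4 cells (Homo sapiens) for cytotoxicity, read by MTT assay, with a stated time of 5 days (a lower number here means that less compound is tolerated, a higher number that more compound is tolerated), compound 1 gives 10000 nM. Compound 3 `Cc1cc(C)cc(S(=O)(=O)c2c(C(=O)NC3CN(CC(N)=O)C3)[nH]c3ccc(Cl)cc23)c1` gives 25500 nM, and the step of a 2.6-fold higher number from compound 1 to compound 3 (0.41 log units; beyond the scatter) was modest. Compound 2 `Cc1cc(C)cc(S(=O)(=O)c2c(C(=O)NC3CN(Cc4ccccc4F)C3)[nH]c3ccc(Cl)cc23)c1` reaches only a limit of the assay, > 238000 nM. Compound 4 `Cc1cc(C)cc(S(=O)(=O)c2c(C(=O)NS(=O)(=O)C(F)(F)F)[nH]c3ccc(Cl)cc23)c1` differs from compound 1 in one place: (trifluoromethyl)sulfonyl in place of pyrrolidin-3-yl on an amide-type nitrogen. Within the data shown here, no measured step swaps the ring for a (trifluoromethyl)sulfonyl group, so the two known steps, an at least 23-fold higher number from compound 1 to compound 2 (1.37 log units; beyond the scatter) and a 2.6-fold higher number from compound 1 to compound 3 (0.41 log units; beyond the scatter), bear on it only loosely; both replaced pyrrolidin-3-yl and both raised the number. A small step upward, or none beyond the scatter, is therefore expected: a 2.0-fold higher number from compound 1 to compound 4 (0.30 log units; within the scatter). Compound 4 is estimated at 20000 nM, with a range from 7000 nM to 60000 nM.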

Compound 4, half-maximal cytotoxic concentration: 141000 nM
Compound 4: middle estimate off by 7.1-fold (0.85 log units), on the low side; measured number above the stated range.
By their numbers in this assay, from the lowest: compound 1; then compound 3; then compound 4. At a limit, above all of these: compound 2.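

In this assay, the earlier higher numbers came from replacements that kept a ring on this amide-type nitrogen, but (trifluoromethyl)sulfonyl has no ring and still raises the number (a 14-fold higher number from compound 1 to compound 4 (1.15 log units; beyond the scatter)) and (a 5.5-fold higher number from compound 3 to compound 4 (0.74 log units; beyond the scatter)). A ring at this place is therefore not needed for a higher number among these compounds. The remaining step (an at least 1.6-fold lower number from compound 2 to compound 4 (0.22 log units; that floor lies within the scatter)) rests on a limit and not on a number: (the limit of > 238000 nM in this assay, at which 1 of the 4 values shown sits).

Going by these compounds, whether the trifluoromethyl part matters stays open, since a methylsulfonyl group would test that directly. An open-chain amine at this place is also untested among the compounds shown.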